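This account rests on a few compounds, and the source may have more. Where it says the series, first, only, none or still open, it means among the compounds named here.

Of the compounds shown here, three of a shared core have been measured in an ADME assay on microsomes from liver (Mus musculus) for metabolic stability, read by LC-MS, using NADPH; a lower number here means that the compound disappears faster, a higher number that the compound lasts longer. Compound 1 `Cc1cccnc1Nc1ncc(-c2ccccn2)o1` gives 0.0233 h. Compound 2 `COC(=O)c1cccc(-c2cnc(Nc3ccc(F)cc3)o2)c1` gives 0.0183 h. Compound 3 `CN(c1ccc(F)cc1)c1ncc(-c2cccc(C(=O)O)c2)o1` gives 1.45 h.

Among these three numbers compound 2 stands lowest. Its nearest neighbour is compound 1, whose value lies within the usual scatter of compound 2, so the two cannot be told apart. Compound 3 lies far above compound 2, well beyond the scatter.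

The next compound, compound 4 `Nc1cccc(-c2cnc(Nc3ccc(F)cc3)o2)c1`, has not yet been measured in this assay. It differs from compound 2 in one place: amino in place of methoxycarbonyl on an aromatic carbon. The group that leaves carries a carbonyl and an ether oxygen; the group that enters is a single nitrogen bearing a hydrogen-bond donor.

Within the data shown here, no pair of measured compounds differs by this change, so nothing among the measured compounds sets the size of the step. The author expects compound 4 to give a somewhat longer half-life than compound 2, with the step from compound 2 to compound 4 estimated at a 2.7-fold higher number from compound 2 to compound 4 (0.44 log units; beyond the scatter), a modest change that might not clear the scatter. On that basis compound 4 is estimated at 0.05 h in this assay, within a range from 0.015 h to 0.2 h.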

Compound 4, half-life: 0.0717 h
For compound 4 the middle estimate is 1.4-fold (0.16 log units) below the measured one, and the stated range covers the measured number.
By their numbers in this assay, from the lowest: compounds 2 and 1 (each within the scatter of the next); then compound 4; then compound 3.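

In this assay, among these compounds, this is the first step that can be read at the aromatic carbon meta to a large group: amino in place of methoxycarbonyl gives a 3.9-fold higher number from compound 2 to compound 4 (0.59 log units; beyond the scatter) and this modest step lies beyond the scatter. The half-life therefore does respond to the group at this position, and the exchange that removes a carbonyl and an ether oxygen and brings in a hydrogen-bond donor moves it upward, with compound 4 reaching 0.0717 h on the same scale. Nothing measured here speaks to the reason for this rise.

From the compounds shown here alone, a single step cannot separate the loss of methoxycarbonyl from the gain of amino, so it remains open whether a hydroxyl group, a nitrile or a methyl group on the same carbon would shift the half-life in the same direction. Going by these compounds, it also remains open whether the same exchange would give a step of similar size with a methyl group on the nitrogen that carries the fluorinated ring.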